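Swapping an Aromatic Ring for Cyclopropyl at the Tetrazole

This account rests on a few compounds, and the source may have more. Where it says the series, first, only, none or still open, it means among the compounds named here.

Of the compounds shown here, three sharing one core have been measured in an assay on HEK293 cells for activation of Kir3.1/Kir3.2 (Homo sapiens), read by thallium flux; a higher number here means a larger maximal response, a lower number a smaller maximal response. Compound 1 `Cc1cc(NC(=O)Cn2nnc(-c3ccccc3)n2)n(C2CCCCC2)n1` carries a phenyl group and in this assay compound 1 reaches 92%. Compound 2 `Cc1cc(NC(=O)Cn2nnc(-c3ccccn3)n2)n(C2CCCCC2)n1` has pyridin-2-yl in place of phenyl, and in this assay compound 2 gives 81%, a change of a number 11 percentage points lower from compound 1 to compound 2 (beyond the scatter). Compound 3 `Cc1cc(NC(=O)Cn2nnc(-c3ccnc(F)c3)n2)n(C2CCCCC2)n1` bears 2-fluoropyridin-4-yl, and in this assay compound 3 reaches 95%, the highest of the three numbers; the move a number 3 percentage points higher from compound 1 to compound 3 (within the scatter) lies within the scatter, while a number 14 percentage points higher from compound 2 to compound 3 (beyond the scatter) is beyond it.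

Compound 4 `Cc1cc(NC(=O)Cn2nnc(C3CC3)n2)n(C2CCCCC2)n1` differs from compound 3 by the change (cyclopropyl in place of 2-fluoropyridin-4-yl on an aromatic carbon).

The measured steps all exchange one six-membered aromatic ring for another, and the largest of them, a number 14 percentage points higher from compound 2 to compound 3 (beyond the scatter), is only modest. None of them replaces an aromatic ring with a small non-aromatic ring, so they bear on the present step only loosely. Since every measured variation at this position stayed within a modest range, the estimate for compound 4 is a step of a number 15 percentage points lower from compound 3 to compound 4 (beyond the scatter), with wide uncertainty. Compound 4 is therefore expected to give about 80% in this assay, somewhere between 55% and 100%.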

Compound 4, largest response reached (Emax), in percent of the reference or control that the assay uses: > 68%
Compound 4 gave a limit, no number (the forecaster's own chance of this, stated with the estimate: 0%); the middle value is on the limit's open side.
By their numbers in this assay, from the lowest: compound 2; then compounds 1 and 3 (each within the scatter of the next).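

Compound 4 gives > 68% in this assay, which is a limit and not a number. The steps from compound 1, compound 2 and compound 3 to compound 4 therefore cannot be read. The compounds shown leave open how the response with cyclopropyl compares with those with phenyl, pyridin-2-yl and 2-fluoropyridin-4-yl.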